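The source may hold more compounds than are shown below. What is called first, only, known or untested is meant among the compounds shown, and "the series" means these compounds.

Measured so far:
- compound 1 `COc1cc(Cl)cc(-c2nn(-c3cccc(NC(=O)Nc4ccc(Cl)c(C(F)(F)F)c4)c3)cc2-c2ccncc2)c1`: 98%
- compound 2 `COc1cc(Cl)cc(-c2nn(-c3cccc(NC(=O)Nc4cc(C(F)(F)F)cc(C(F)(F)F)c4)c3)cc2-c2ccncc2)c1`: 91%

In a functional assay on SF-295 cells (Homo sapiens) for inhibition, read by sulforhodamine B assay, with a stated time of 48 h, tested at 0.1 uM (on this read-out lower numbers stand for a stronger effect and higher numbers for a weaker effect at the one concentration tested), compound 1 gives 98%. Compound 2 gives 91% in this assay. For the measured compounds named here, the two numbers lie within the usual scatter of each other, so neither compound can be placed ahead of the other; both leave most of the cell growth in place at the concentration tested, and no step between them is worth reading.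

Compound 3 `COc1cc(Cl)cc(-c2nn(-c3cccc(NC(=O)c4cccc(C(F)(F)F)c4)c3)cc2-c2ccncc2)c1` has not yet been measured in this assay. It differs from compound 1 in one place: 3-(trifluoromethyl)phenyl in place of (4-chloro-3-(trifluoromethyl)phenyl)amino on a carbonyl carbon. The shared core of compound 1 is kept as it stands.

Going by the values given here, with only two measured compounds, both weak and within scatter of each other, there is no measured step to lean on. The expectation for compound 3 in this assay is a step of a number 4 percentage points lower from compound 1 to compound 3 (within the scatter), that is, no change beyond the scatter, because compound 1 at 98% already sits close to the no-effect end of the read-out and has little room to move upward. Compound 3 is therefore estimated at 94%, with a range from 80% to 105%.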

Compound 3, a percentage reported as activity, at one concentration (the size of the read-out at that concentration, not a potency): 90%
Beside the measured number, compound 3's estimate is 4 percentage points above it; measured number inside the range.
By their numbers in this assay, from the lowest: compounds 3, 2 and 1 (each within the scatter of the next).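

In this assay the exchange of (4-chloro-3-(trifluoromethyl)phenyl)amino for 3-(trifluoromethyl)phenyl on the carbonyl carbon, whose other neighbour is an amide-type nitrogen, is a number 8 percentage points lower from compound 1 to compound 3 (within the scatter) and so cannot be read as a change in effect. For the compounds shown here, this is the first single-place comparison: at this position, the chlorine and the hydrogen-bond donor of the leaving group can go without a shift beyond the scatter at the one concentration tested. No available evidence bears on why this exchange leaves the read-out within the scatter.

As far as these compounds go, whether another type of group on this carbonyl carbon, such as morpholine or a phenyl ring carrying a carboxylic acid, would give a step beyond the scatter remains open. Also open, from the compounds shown here alone, is whether a change elsewhere on the shared core would move the read-out when this position alone has not.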